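From 4-(trifluoromethyl)phenyl to naphthalen-2-yl at the assay limit

The source may report more compounds than this note shows. Statements on the series, on what has been measured and on what is new or still open speak of the compounds shown alone.

- Compound 1 `O=C(O)CCCCCCC(=O)Nc1ccc(C2=C(c3ccc(O)cc3)C3CC(S(=O)(=O)Oc4ccccc4C(F)(F)F)C2O3)cc1` reads > 100000 nM as a limit
- Compound 2 `O=C(O)CCCCCCC(=O)Nc1ccc(C2=C(c3ccc(O)cc3)C3CC(S(=O)(=O)Oc4ccc(C(F)(F)F)cc4)C2O3)cc1` reads > 100000 nM as a limit

In an ADME assay on Vero cells (Chlorocebus sabaeus) for inhibition, read by MTT assay, with a stated time of 72 h (on this read-out lower numbers stand for stronger inhibition and higher numbers for weaker inhibition), compound 2 reads > 100000 nM as a limit and not as a number. Within the data shown here, the only measured step is a step that the two limits leave unreadable from compound 1 to compound 2 and it offers no size to carry forward. Compound 3 `O=C(O)CCCCCCC(=O)Nc1ccc(C2=C(c3ccc(O)cc3)C3CC(S(=O)(=O)Oc4ccc5ccccc5c4)C2O3)cc1` brings the change (naphthalen-2-yl in place of 4-(trifluoromethyl)phenyl on an oxygen), with naphthalen-2-yl in place of 4-(trifluoromethyl)phenyl on an oxygen. What bears on this change is the limit of > 100000 nM in this assay, at which 2 of the 2 values shown sit, so no clear step in either direction is expected in this assay, and another limit is the likeliest report for compound 3. The estimated step, no larger than the scatter, is a number no higher from compound 2 to compound 3 (the limit leaves the size open) in size. For compound 3 the expected value is 100000 nM (estimated range 50000 nM to 200000 nM).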

Compound 3, half-maximal inhibitory concentration: > 100000 nM
Compound 3 gave a limit, no number (the forecaster's own chance of this, stated with the estimate: 85%); the middle value lies on the limit itself.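

In this assay, among these compounds, compound 3 reads > 100000 nM as a limit, not a number, so no step among compound 1, compound 2 and compound 3 can be read. The compounds shown leave open whether these groups on the oxygen differ in effect at all, with every value at one limit: the limit of > 100000 nM in this assay, at which 3 of the 3 values shown sit.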